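The source may hold more compounds than are shown below. What is called first, only, known or untested is meant among the compounds shown, and "the series" means these compounds.

The series is followed in a functional assay on PC-3 cells (Homo sapiens) for cytotoxicity, read by sulforhodamine B assay, with a stated time of 72 h; a higher number here means a weaker inhibitor of growth, a lower number a stronger inhibitor of growth. Compound 1 `CC(=O)N1c2ccccc2CCC1C(=O)Nc1cc(C(F)(F)F)cc(C(F)(F)F)c1` gives only a limit there: in this assay compound 1 reads > 70000 nM, a value that sits at the limit of > 70000 nM in this assay, at which 1 of the 3 values shown sits. Compound 2 `O=C(Nc1ccc(O)cc1)C1CCc2ccccc2N1` likewise gives only a limit, and in this assay compound 2 reads > 100000 nM, which sits at the limit of > 100000 nM in this assay, at which 1 of the 3 values shown sits. Among the compounds with values here, compound 3 `COc1ccc(NC(=O)C2CCc3ccccc3N2)cc1` is the one member with a measured number, and in this assay compound 3 gives 56900 nM. Within the data shown here, the single step between measured compounds that differ in one place is an at least 1.7-fold lower number from compound 2 to compound 3 (0.24 log units; that floor lies within the scatter); as it starts from a limit, it is only a floor, and that floor lies within the scatter. Among the measured compounds shown here, compound 1 thus stands at a limit, with no measured step reaching it.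

Compound 4 `CCCCCCCCC(=O)N1c2ccccc2CCC1C(=O)Nc1cc(C(F)(F)F)cc(C(F)(F)F)c1` differs from compound 1 by heptyl in place of hydrogen on a saturated chain carbon bound to a carbonyl carbon. For the measured compounds named here, no measured pair in the set changes the acyl group, so the step from compound 1 to compound 4 has no direct precedent, and the one measured step concerns another part of the molecule. With compound 1 at a limit, only a loose expectation can be drawn. For compound 4 the expected step is an at least 1.7-fold lower number from compound 1 to compound 4 (0.24 log units; that floor lies within the scatter). For compound 4 the estimate in this assay is 40000 nM, with a range from 8000 nM to 150000 nM, and a limit rather than a number remains a real possibility.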

Compound 4, concentration for 50% growth inhibition: 7430 nM
For compound 4 the middle estimate is 5.4-fold (0.73 log units) above the measured one, and the stated range ends above it.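

In this assay, within the data shown here, the change from acetyl to octylcarbonyl on the shared core gives an at least 9.4-fold lower number from compound 1 to compound 4 (0.97 log units; beyond the scatter), the first step to clear the scatter and the first to touch the acyl group, as the earlier step concerned another part of the molecule. Growth inhibition therefore responds to a change at this place, and the heptyl addition moves the read-out from a limit to a measured number, towards a stronger inhibitor of growth. The true size of the step stays open because compound 1 gives only a limit, so the printed size is a floor: the limit of > 70000 nM in this assay, at which 1 of the 4 values shown sits.

With only two acyl groups compared, the compounds shown cannot tell whether the effect grows steadily with chain length, peaks at some intermediate chain such as butyryl or hexanoyl, or continues to a longer chain such as dodecanoyl. They also leave open whether the chain itself is enough, or whether one ending in an amine or a carboxylic acid would give a similar step, and whether octylcarbonyl acts the same way on the core of compound 3.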